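Sulfonamide aryl variation in the shared core series

The source may report more compounds than this note shows. Statements on the series, on what has been measured and on what is new or still open speak of the compounds shown alone.

Compound 3 `O=C(NCc1ccc(CNS(=O)(=O)c2cccc(F)c2)cc1)c1ccc(CNc2ncccn2)cc1` is the point of departure. In an assay on MDA-MB-231 cells for binding affinity to C-X-C chemokine receptor type 4 (Homo sapiens), read by microscopy, with stated times of 10 min and 30 min (a lower number here means that less compound is needed, a higher number that more compound is needed for the effect), compound 3 gives 1000 nM, level at the digits shown with compound 2 `O=C(NCc1ccc(CNS(=O)(=O)c2ccc(-c3ccc(F)cc3)cc2)cc1)c1ccc(CNc2ncccn2)cc1`, which gives 1000 nM; together these are the highest numbers of the three, while compound 1 `O=C(NCc1ccc(CNS(=O)(=O)c2ccc(Cl)cc2)cc1)c1ccc(CNc2ncccn2)cc1` gives 100 nM, the lowest. The measured steps are a 10-fold higher number from compound 1 to compound 2 (1.00 log units; beyond the scatter) and a 10-fold higher number from compound 1 to compound 3 (1.00 log units; beyond the scatter). Compound 4 `O=C(NCc1ccc(CNS(=O)(=O)c2cccc(C(F)(F)F)c2)cc1)c1ccc(CNc2ncccn2)cc1` carries the change (trifluoromethyl in place of fluoro on an aromatic carbon). Among the measured compounds shown here, no measured step covers fluoro against trifluoromethyl at this position, so the expectation rests only on the observation that both departures from compound 1 raised the number. Compound 4 is therefore expected near 1000 nM, between 300 nM and 3000 nM. That estimate means a step of no change at the digits printed from compound 3 to compound 4 (within the scatter), within the scatter.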

Compound 4, effective concentration (reported as EC, without a stated level of effect): 1000 nM
The estimate for compound 4 equals the measured number at the digits printed, within the range that was stated.
By their numbers in this assay, from the lowest: compound 1; then compounds 2, 3 and 4 (each within the scatter of the next).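

In this assay, going from 3-fluorophenyl to 3-(trifluoromethyl)phenyl gives no change at the digits printed from compound 3 to compound 4 (within the scatter), so the two groups cannot be told apart at this position. The 4-chlorophenyl sulfonamide remains separate from the new compound, with a 10-fold higher number from compound 1 to compound 4 (1.00 log units; beyond the scatter), and trifluoromethyl in place of fluoro does not close that gap. No available evidence bears on either step. From the compounds shown here alone, it remains open whether an amine or a carboxylic acid in place of trifluoromethyl on this ring would shift the number from the level of compounds 3 and 4.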